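The compounds below may be only part of what the source reports. "The series", "measured", "known", "first", "only" and "open" are said of these compounds alone.

Compound 1 `CC(C)(C)OC(=O)N1CCC2(CC1)CC(CCCOc1ccc(S(C)(=O)=O)c(F)c1)C2`: 9 nM
Compound 2 `CC(C)(C)COC(=O)N1CCC2(CC1)CC(CCCOc1ccc(S(C)(=O)=O)c(F)c1)C2`: 31 nM
Compound 3 `CCc1cnc(N2CCC3(CC2)CC(CCCOc2ccc(S(C)(=O)=O)cc2)C3)nc1`: 31 nM

These three compounds were tested in a functional assay on cells for agonist activity at Glucose-dependent insulinotropic receptor (Homo sapiens), read by HTRF and cAMP accumulation, with a stated time of 30 min; a lower number here means that less compound is needed, a higher number that more compound is needed for the effect. Compound 3 stands level with compound 2 at the digits printed; together they give the highest numbers of the three. Compound 1 gives the lowest number, and the gap between compound 3 and compound 1 lies beyond the scatter.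

Compound 4 `CCc1cnc(N2CCC3(CC2)CC(CCCOc2ccc(S(C)(=O)=O)c(F)c2)C3)nc1` is the next compound. It differs from compound 3 in one place: fluoro in place of hydrogen on an aromatic carbon. Within the data shown here, the only measured step that changes a single place is a 3.4-fold higher number from compound 1 to compound 2 (0.54 log units; beyond the scatter), and it concerns the group on the oxygen next to the carbonyl, not the aromatic ring; it therefore does not bear on this change. Among the measured compounds shown here, compound 1 and compound 2 carry the fluoro that compound 4 gains, while compound 3 lacks it, but those compounds also differ from compound 3 elsewhere, so their values show only that fluoro-bearing compounds span a range from the lowest to the highest number seen here.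

For the measured compounds named here, with no measured step on the fluoro itself, a step within the scatter, or a modest lowering, is expected for compound 4, giving an estimated 20 nM (range 7 nM to 60 nM), that is an expected step of a 1.6-fold lower number from compound 3 to compound 4 (0.19 log units; within the scatter).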

Compound 4, half-maximal effective concentration: 123 nM
Compound 4: middle estimate off by 6.2-fold (0.79 log units), on the low side, and the stated range ends below it.
By their numbers in this assay, from the lowest: compound 1; then compounds 2 and 3 (each within the scatter of the next); then compound 4.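

Among these compounds, compound 4 gives the first direct reading of this change in this assay: placing fluoro on the aromatic carbon ortho to the methylsulfonyl group gives a 4.0-fold higher number from compound 3 to compound 4 (0.60 log units; beyond the scatter), so more compound is needed for the effect, and this ring position is not indifferent to the swap of hydrogen for fluoro. With the fluoro held constant, the group on the ring amine nitrogen also matters: 5-ethylpyrimidin-2-yl in place of neopentyloxycarbonyl gives a 4.0-fold higher number from compound 2 to compound 4 (0.60 log units; beyond the scatter), and in place of tert-butoxycarbonyl it gives a 14-fold higher number from compound 1 to compound 4 (1.14 log units; beyond the scatter), so the compounds that carry the fluoro differ widely according to that group. Nothing among the available data explains why the fluoro raises the number in this compound pair.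

The compounds shown leave open whether fluoro gives a step of the same size when tert-butoxycarbonyl or neopentyloxycarbonyl sits on the amine nitrogen, since only the 5-ethylpyrimidin-2-yl pair isolates this change. They also leave open how chloro, methyl, methoxy or a nitrile would behave on the same aromatic carbon, and what fluoro would do on the other carbons of that ring.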